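The source may hold more compounds than are shown below. What is called first, only, known or untested is meant among the compounds shown, and "the series" means these compounds.

In a functional assay on A549 cells (Homo sapiens) for cytotoxicity, read by MTT assay, with a stated time of 72 h (on this read-out lower numbers stand for stronger inhibition and higher numbers for weaker inhibition), compound 1 `COc1ncc(-c2ccc3nccc(N4CCCC4)c3c2)cc1NS(=O)(=O)c1ccc(F)cc1F` gives 3410 nM. Compound 2 `CCN(Cc1ccc(-c2ccnc3ccc(-c4cnc(OC)c(NS(=O)(=O)c5ccc(F)cc5F)c4)cc23)cc1)C1CCCCC1` differs from compound 1 at more than one place, so no single step connects them; in this assay compound 2 gives 20.2 nM, the lower of the two numbers shown, and its gap to compound 1 lies far beyond the scatter. Compound 3 `COc1ncc(-c2ccc3nccc(-c4ccc(CN5CCN(C)CC5)cc4)c3c2)cc1NS(=O)(=O)c1ccc(F)cc1F` is not yet measured. It differs from compound 2 by 4-methylpiperazin-1-yl in place of cyclohexyl(ethyl)amino on a saturated chain carbon bound to an aromatic carbon. Among the compounds with values here, no measured pair covers this change, so the expectation rests on compound 2 alone. The arrangement that compound 2 carries on the saturated chain carbon bound to an aromatic carbon is kept in kind, so only a small move toward a higher number, at the edge of the scatter, is expected, giving an estimated step of a 2.2-fold higher number from compound 2 to compound 3 (0.35 log units; beyond the scatter). Compound 3 is estimated at 45 nM, with a range of 12 nM to 180 nM.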

Compound 3, half-maximal inhibitory concentration: 13.3 nM
Compound 3: middle estimate off by 3.4-fold (0.53 log units), on the high side; measured number inside the range.
By their numbers in this assay, from the lowest: compounds 3 and 2 (each within the scatter of the next); then compound 1.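

In this assay, within the data shown here, the change to 4-methylpiperazin-1-yl in place of cyclohexyl(ethyl)amino on a saturated chain carbon bound to an aromatic carbon gives a 1.5-fold lower number from compound 2 to compound 3 (0.18 log units; within the scatter) and is the first one-place comparison. At this position, a six-membered non-aromatic ring of carbon only and a six-membered non-aromatic ring with 2 hetero atoms cannot be told apart by this read-out, so the exchange is tolerated here. Nothing measured on these compounds explains this result.

Compound 1 differs from compound 2 and compound 3 at more than one place, so it gives no one-place reading on this position. Still open, as far as these compounds go, is whether a morpholin-4-yl group, a carboxylic acid or a longer chain on the same saturated chain carbon would keep the number in this range.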